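This account rests on a few compounds, and the source may have more. Where it says the series, first, only, none or still open, it means among the compounds named here.

Working notes on the series. In an ADME assay on MT4 cells (Homo sapiens) for cytotoxicity (a lower number here means that less compound is tolerated, a higher number that more compound is tolerated), compound 1 `Cc1ccc(S(=O)(=O)n2c(=O)[nH]c3ccc(Cl)cc32)cc1` gives 134000 nM. Compound 2 `Cc1cc(C)c(C)c(S(=O)(=O)n2c(=O)[nH]c3ccc(Cl)cc32)c1C` gives >= 342000 nM, which is a limit of the assay and not a number. From the compounds shown here alone, compound 2 therefore stands at the limit of >= 342000 nM in this assay, at which 1 of the 2 values shown sits, so its true position in this assay remains unknown.

Compound 3 `Cc1c(C)c(C)c(S(=O)(=O)n2c(=O)[nH]c3ccc(Cl)cc32)c(C)c1C` follows from compound 2 by one change, methyl in place of hydrogen on an aromatic carbon. The entering methyl is ortho to two methyl groups, meta to two methyl groups and para to a large group.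

Going by the values given here, no measured pair differs in one place only, so the size of this change in this assay has no direct precedent. No shift beyond the usual scatter is expected, and any movement is expected to be a modest fall, with another limit a real possibility. The expected step of an at least 1.3-fold lower number from compound 2 to compound 3 (0.11 log units; that floor lies within the scatter) is therefore small. For compound 3 the estimated value is 260000 nM, with an expected range from 100000 nM to 345000 nM.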

Compound 3, half-maximal cytotoxic concentration: 236000 nM
Beside the measured number, compound 3's estimate is 1.1-fold (0.04 log units) above it; low and high end bracket the measured number.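

In this assay, going by these compounds alone, methyl in place of hydrogen on this aromatic carbon, ortho to two methyl groups, meta to two methyl groups and para to a large group, now has a first step: an at least 1.4-fold lower number from compound 2 to compound 3 (0.16 log units; that floor lies within the scatter), and this is the only step that can be read so far. The step gives the change a floor and no exact size, and compound 3 adds a measured number at this end of the series, where the preceding compound in the step offers none. The floor is all that can be stated because one end of the step is a limit of the assay and not a number: the limit of >= 342000 nM in this assay, at which 1 of the 3 values shown sits.

From the compounds shown here alone, how far the true step lies beyond that floor stays open, and with a single step it also stays open whether this aromatic carbon has any real bearing on the tolerated concentration in this assay. Equally open, going by these compounds, is how an amine, a carboxylic acid or a longer chain on the same aromatic carbon would read against methyl and hydrogen.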